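Compound 2 to compound 3: piperazine replaced at the carbonyl

A few compounds are considered here, and "the series" means these few. Any claim that something is new, unique, unknown or untested is made for them only; others in the source may bear on it.

In a functional assay on PC-3 cells (Homo sapiens) for inhibition, read by sulforhodamine B assay, with a stated time of 72 h (a higher number here means a weaker inhibitor, a lower number a stronger inhibitor), compound 2 (`CN1CCN(C(=O)c2c(N)sc(-c3ccc(Cl)cc3)c2-c2ccc(Cl)cc2)CC1`) gives 13100 nM, within the scatter of compound 1 (`CC1CN(C(=O)c2c(N)sc(-c3ccc(Cl)cc3)c2-c2ccc(Cl)cc2)CCN1`) at 7210 nM. Compound 3 (`COc1ccc(CNC(=O)c2c(N)sc(-c3ccc(Cl)cc3)c2-c2ccc(Cl)cc2)cc1`) carries the change (4-methoxybenzyl)amino in place of 4-methylpiperazin-1-yl on a carbonyl carbon. Going by the values given here, the only measured step, a 1.8-fold higher number from compound 1 to compound 2 (0.26 log units; within the scatter), merely exchanges 3-methylpiperazin-1-yl for 4-methylpiperazin-1-yl, so it offers little guide to a change of the whole group. No shift beyond the scatter is expected, and the expected step is a 1.6-fold lower number from compound 2 to compound 3 (0.21 log units; within the scatter). For compound 3 the estimate is 8000 nM, with an expected range of 2500 nM to 25000 nM.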

Compound 3, half-maximal inhibitory concentration: 29500 nM
For compound 3 the middle estimate is 3.7-fold (0.57 log units) below the measured one, outside the stated range (above it).
By their numbers in this assay, from the lowest: compounds 1 and 2 (each within the scatter of the next); then compound 3.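

In this assay, replacing either methylpiperazine with (4-methoxybenzyl)amino on the carbonyl carbon gives a 2.3-fold higher number from compound 2 to compound 3 (0.35 log units; beyond the scatter) and a 4.1-fold higher number from compound 1 to compound 3 (0.61 log units; beyond the scatter). Going by these compounds alone, both steps are modest, but they are the first at this place to lie beyond the scatter, so exchanging the whole group weakens inhibition where moving the methyl group showed no clear change. No measurement available here accounts for this shift.

As far as these compounds go, it remains open whether the weaker inhibition follows the amide hydrogen, the aromatic ring or the methoxy group. A plain benzylamino group or a morpholine on the carbonyl carbon would help separate these.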